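Adding methoxy to compound 2: expected step

This account rests on a few compounds, and the source may have more. Where it says the series, first, only, none or still open, it means among the compounds named here.

Going by the values given here, compound 2 `CCc1nc(-c2ccc(COc3cccc(C(=O)NO)c3)cc2)no1` gives the highest of the two numbers so far in an assay on isolated protein for inhibition of sphingomyelin phosphodiesterase (Homo sapiens), read by fluorescence, with a stated time of 30 min (on this read-out higher numbers stand for weaker inhibition and lower numbers for stronger inhibition), at 34700 nM. Among the compounds with values here, its nearest neighbour, compound 1 `COc1ccc(C(=O)NO)cc1OCc1ccc(-c2cccnc2)cc1`, gives 4970 nM in this assay, a lower number beyond the scatter; the two structures differ in more than one place, so no single step is isolated. Compound 3 `CCc1nc(-c2ccc(COc3cc(C(=O)NO)ccc3OC)cc2)no1` carries methoxy in place of hydrogen on an aromatic carbon relative to compound 2. Within the data shown here, no measured pair shows this change alone, so the step expected in this assay is modest, toward a lower number, and may not exceed the scatter. Compound 3 is estimated at 12000 nM, within 4000 nM to 35000 nM. The expected step is a 2.9-fold lower number from compound 2 to compound 3 (0.46 log units; beyond the scatter).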

Compound 3, half-maximal inhibitory concentration: 8220 nM
Compound 3: middle estimate off by 1.5-fold (0.16 log units), on the high side, and the stated range covers the measured number.
By their numbers in this assay, from the lowest: compounds 1 and 3 (each within the scatter of the next); then compound 2.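

In this assay, going by these compounds alone, methoxy in place of hydrogen on the aromatic carbon para to the hydroxycarbamoyl group gives a 4.2-fold lower number from compound 2 to compound 3 (0.63 log units; beyond the scatter), the first single-place reading. With that methoxy present, 5-ethyl-1,2,4-oxadiazol-3-yl in place of pyridin-3-yl gives a 1.7-fold higher number from compound 1 to compound 3 (0.22 log units; within the scatter), so this assay does not separate those two groups. No evidence bears on the cause of either step.

Open: whether the methoxy step holds with pyridin-3-yl in the series, and whether hydroxy, ethoxy or fluorine on the same carbon reads like methoxy.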